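Methyl for dimethylamino in a series held at a limit

This account rests on a few compounds, and the source may have more. Where it says the series, first, only, none or still open, it means among the compounds named here.

In a functional assay on HepG2 cells (Homo sapiens) for antiproliferative activity, read by XTT assay, with a stated time of 72 h (a lower number here means a stronger inhibitor, a higher number a weaker inhibitor), compound 1 `CNc1ncnc2c1c(-c1ccsc1)cn2[C@@H]1O[C@H](CO)[C@@H](O)[C@H]1O` gives > 20000 nM, which is a limit. Compound 2 `CN(C)c1ncnc2c1c(-c1ccsc1)cn2[C@@H]1O[C@H](CO)[C@@H](O)[C@H]1O` gives > 20000 nM, also a limit. Compound 3 `CN(C)c1ncnc2c1c(-c1cc3ccccc3o1)cn2[C@@H]1O[C@H](CO)[C@@H](O)[C@H]1O` gives > 20000 nM, again a limit. Compound 2 therefore has no number of its own and stands with the others at the limit of > 20000 nM in this assay, at which 3 of the 3 values shown sit.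

Compound 4 `Cc1ncnc2c1c(-c1ccsc1)cn2[C@@H]1O[C@H](CO)[C@@H](O)[C@H]1O` carries methyl in place of dimethylamino on an aromatic carbon, next to the ring nitrogen: methyl in place of dimethylamino on an aromatic carbon. Going by the values given here, two measured steps bear on this, a step that the two limits leave unreadable from compound 1 to compound 2 and a step that the two limits leave unreadable from compound 2 to compound 3, but neither has a readable size to carry over. Neither tests this replacement, so only a tentative move toward a stronger inhibitor is expected, an at least 3.3-fold lower number from compound 2 to compound 4 (0.52 log units; beyond the scatter). Compound 4 is estimated at 6000 nM, within a range of 400 nM to 20000 nM.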

Compound 4, half-maximal inhibitory concentration: 4720 nM
For compound 4 the middle estimate is 1.3-fold (0.10 log units) above the measured one; low and high end bracket the measured number.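

In this assay, this aromatic carbon gives the first readable change: methyl in place of dimethylamino is an at least 4.2-fold lower number from compound 2 to compound 4 (0.62 log units; beyond the scatter), and methyl in place of methylamino is an at least 4.2-fold lower number from compound 1 to compound 4 (0.62 log units; beyond the scatter). The steps among compound 1, compound 2 and compound 3 cannot be read. Compound 4 alone has a number of its own: the limit of > 20000 nM in this assay, at which 3 of the 4 values shown sit.

Going by these compounds, the full size of both new steps stays open. On these data alone, it is also open whether an ethyl or a methoxy group on this carbon would give a number rather than a limit.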